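Three Measured Compounds, One Still to Be Measured

The source may hold more compounds than are shown below. What is called first, only, known or untested is meant among the compounds shown, and "the series" means these compounds.

Compound 1 `Oc1ccc(-c2cc(-c3cccc(O)c3)nc(-c3cccc(O)c3)c2)cc1`: 0%
Compound 2 `Oc1cccc(-c2cc(-c3ccccc3O)cc(-c3cccc(O)c3)n2)c1`: 0%
Compound 3 `Oc1ccc(-c2cc(-c3ccccc3O)cc(-c3ccccc3O)n2)cc1`: 0.3%

In an assay on isolated protein for inhibition of DNA topoisomerase 1 (Homo sapiens), with a stated time of 30 min, tested at 100 uM (a lower number here means less inhibition, a higher number more inhibition at the concentration tested (going by the name of the read-out)), compound 1 gives 0%, compound 2 gives 0% and compound 3 gives 0.3%; all three values lie within the scatter of one another. Going by the values given here, the one counted change among the measured compounds is 4-hydroxyphenyl in place of 2-hydroxyphenyl on an aromatic carbon, and it gave no change at the digits printed from compound 2 to compound 1 (within the scatter). The difference between the cores of compound 2 and compound 3 is not broken down here.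

Compound 4 `Oc1ccc(-c2cc(-c3ccccc3O)cc(-c3ccc(O)cc3)n2)cc1` has not yet been tested in this assay. It differs from compound 3 by 4-hydroxyphenyl in place of 2-hydroxyphenyl on an aromatic carbon, the same kind of change as that from compound 2 to compound 1, though the surroundings differ: in compound 2 the place is meta to two 3-hydroxyphenyl groups and opposite the ring nitrogen, whereas in compound 3 it is next to the ring nitrogen, meta to a 2-hydroxyphenyl group and meta to a 4-hydroxyphenyl group. The expected step is a number 0.2 percentage points higher from compound 3 to compound 4 (within the scatter), resting on no change at the digits printed from compound 2 to compound 1 (within the scatter). Compound 4 is therefore estimated at 0.5%, expected to fall between 0% and 6%.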

Compound 4, a percentage reported as inhibition, at one concentration (the size of the read-out at that concentration, not a potency): 0.4%
Compound 4: the middle estimate sits 0.1 percentage points above what was measured, and the stated range covers the measured number.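

In this assay, placing 4-hydroxyphenyl in place of 2-hydroxyphenyl on an aromatic carbon gave a number 0.1 percentage points higher from compound 3 to compound 4 (within the scatter). Set beside the earlier case, the change reads the same on both cores: the same change on two cores in this assay, no change at the digits printed (within the scatter) from compound 2 to compound 1 and a number 0.1 percentage points higher (within the scatter) from compound 3 to compound 4, 0.1 percentage points apart, within the scatter of two such steps. Going by these compounds alone, this agreement does not show that the change is without consequence in general: all the compounds involved show almost no inhibition at the concentration tested, so the two steps say only that the number stayed flat, and they cannot tell how the change would carry to a core that inhibits clearly.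

The compounds shown carry only hydroxyphenyl groups on the shared core, which leaves open how an aminophenyl group or a benzoic acid group in the same place would read in this assay. They also leave open whether any of these compounds has a measurable potency, since a single tested concentration gives none.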